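This account rests on a few compounds, and the source may have more. Where it says the series, first, only, none or still open, it means among the compounds named here.

Three compounds share one core and differ only in the aromatic group attached to it. Compound 1 `COc1ccc(C2=Nc3c(C(C)(C)C)nn(CCCO)c3C(=O)NC2)cc1-c1cnn(C)c1` carries a 1-methyl-1H-pyrazol-4-yl group, compound 2 `COc1ccccc1-c1cc(C2=Nc3c(C(C)(C)C)nn(CCCO)c3C(=O)NC2)ccc1OC` a 2-methoxyphenyl group, and compound 3 `COc1ccc(C2=Nc3c(C(C)(C)C)nn(CCCO)c3C(=O)NC2)cc1-c1cnc(N(C)C)cc1C` a 6-(dimethylamino)-4-methylpyridin-3-yl group. In an ADME assay on microsomes from liver (Homo sapiens) for metabolic stability (a lower number here means that the compound disappears faster, a higher number that the compound lasts longer), compound 1 gives 2 h and compound 2 gives 1.37 h. In this assay compound 3 gives 0.7 h, the lowest of the three numbers, although only its gap to compound 1 lies beyond the scatter. The two measured steps that end at this group were a 2.9-fold lower number from compound 1 to compound 3 (0.46 log units; beyond the scatter) and a 2.0-fold lower number from compound 2 to compound 3 (0.29 log units; within the scatter).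

Compound 4 `COc1ccc(-c2cc(C3=Nc4c(C(C)(C)C)nn(CCCO)c4C(=O)NC3)ccc2OC)cn1` is the next variation: 6-methoxypyridin-3-yl in place of 6-(dimethylamino)-4-methylpyridin-3-yl on an aromatic carbon. Within the data shown here, no measured compound carries the entering group, so the only guide is that arriving at the leaving group gave lower numbers both times, and departing from it may give a somewhat higher one. Compound 4 is therefore expected to show a step of a 1.7-fold higher number from compound 3 to compound 4 (0.23 log units; within the scatter), a modest rise that may still sit within the scatter. Compound 4 is estimated at 1.2 h in this assay. For compound 4 the expected range is estimated to run from 0.6 h to 2.4 h.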

Compound 4, half-life: 2 h
Estimate against measurement, compound 4: 1.7-fold (0.22 log units) below; the measured number falls inside the stated range.
By their numbers in this assay, from the lowest: compounds 3, 2, 1 and 4 (each within the scatter of the next, the first and the last beyond it).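

In this assay there is a 2.9-fold higher number from compound 3 to compound 4 (0.46 log units; beyond the scatter) when 6-methoxypyridin-3-yl replaces 6-(dimethylamino)-4-methylpyridin-3-yl, which shows that a second group at this position, on the aromatic carbon ortho to the methoxy group, also stands clear of the scatter against the dimethylamino-bearing group. The new group shows a 1.5-fold higher number from compound 2 to compound 4 (0.16 log units; within the scatter) and no change at the digits printed from compound 1 to compound 4 (within the scatter), so the 1-methyl-1H-pyrazol-4-yl, 2-methoxyphenyl and 6-methoxypyridin-3-yl groups cannot be told apart in this measurement, even though they are different aromatic groups. Compound 3 now differs beyond the scatter from two of the three other compounds, compound 1 and compound 4, while its gap to compound 2 stays within the scatter.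

No supporting measurement is available to explain the difference seen with compound 3. As far as these compounds go, it also remains open how a pyridin-3-yl group carrying only a dimethylamino group, or only a methyl group, would read here, so the part of the larger group that goes with the lower number cannot yet be singled out.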